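The source may report more compounds than this note shows. Statements on the series, on what has been measured and on what is new or still open speak of the compounds shown alone.

Compound 3 (`Clc1ccc(CNc2ccnc(N3CCC4(CCN(CC5CCCN5)C4)CC3)n2)c(Cl)c1`) stands highest of the three numbers in a physicochemical assay for solubility, read by chemiluminescence, measured as kinetic solubility (a lower number here means a less soluble compound, a higher number a more soluble compound), at 270 ug/mL against compound 1 (`O=C(C1CCCN1)N1CCC2(CCN(c3nccc(NCc4ccc(Cl)cc4Cl)n3)CC2)C1`) at 79 ug/mL and compound 2 (`O=C(C1CCCCC1)N1CCC2(CCN(c3nccc(NCc4ccc(Cl)cc4Cl)n3)CC2)C1`) at 3 ug/mL on the same scale. Compound 4 (`Fc1ccc(CNc2ccnc(N3CCC4(CCN(CC5CCCN5)C4)CC3)n2)c(F)c1`) differs from compound 3 in one place (2,4-difluorophenyl in place of 2,4-dichlorophenyl on a saturated chain carbon bound to a nitrogen on an aromatic ring), with 2,4-difluorophenyl in place of 2,4-dichlorophenyl. For the measured compounds named here, no measured step touches this group. The large (a 26-fold lower number from compound 1 to compound 2 (1.42 log units; beyond the scatter)) and (a 90-fold higher number from compound 2 to compound 3 (1.95 log units; beyond the scatter)) steps and the modest (a 3.4-fold higher number from compound 1 to compound 3 (0.53 log units; beyond the scatter)) step all change another group, so they bear on it only indirectly and give no direct guide to its size. The expected change is small (a 1.3-fold higher number from compound 3 to compound 4 (0.10 log units; within the scatter)) and no large step is expected. Going by the values given here, for compound 4 the estimated value is 340 ug/mL with an expected range of 170 ug/mL to 650 ug/mL (wide, as this swap has no measured precedent).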

Compound 4, solubility: 160 ug/mL
Compound 4: middle estimate off by 2.1-fold (0.33 log units), on the high side; measured number below the stated range.
By their numbers in this assay, from the lowest: compound 2; then compound 1; then compounds 4 and 3 (each within the scatter of the next).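

Swapping 2,4-dichlorophenyl for 2,4-difluorophenyl on a saturated chain carbon bound to a nitrogen on an aromatic ring gives the first reading at this position in this assay (a 1.7-fold lower number from compound 3 to compound 4 (0.23 log units; within the scatter)). Unlike the earlier steps, which changed another group and lay beyond the scatter, this one leaves compound 3 and compound 4 not separable in this read-out. No measurement at hand accounts for the result.

Open, going by these compounds, is whether plain phenyl, or a methoxy group or nitrile in place of the halogens, would also stay within the scatter. Also open, on these data alone, is whether the same swap would read alike with the cyclohexylcarbonyl group of compound 2.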